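A few compounds are considered here, and "the series" means these few. Any claim that something is new, unique, unknown or untested is made for them only; others in the source may bear on it.

Of the compounds shown here, three have numbers so far in an ADME assay on microsomes (Mus musculus) for metabolic stability; a higher number here means faster removal of the compound, a lower number slower removal. Compound 1 (`CNC(=O)[C@@H]1CCCN1S(=O)(=O)c1ccc(Cl)c(COc2cccc3c(C(F)(F)F)cc(C)nc23)c1Cl`) gives 1380 mL/min/kg, compound 2 (`CNC(=O)[C@@H]1CCCN1S(=O)(=O)c1cccc(COc2cccc3c(C(F)(F)F)cc(C)nc23)c1`) gives 767 mL/min/kg, and compound 3 (`Cc1cc(C(F)(F)F)c2cccc(OCc3c(Cl)ccc(S(=O)(=O)N4CCC[C@H]4C(N)=O)c3Cl)c2n1`) gives 12600 mL/min/kg. That last number is the highest of the three and lies beyond the scatter from both of the others.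

The next compound to be measured is compound 4 (`Cc1cc(C(F)(F)F)c2cccc(OCc3c(Cl)ccc(S(=O)(=O)N4CCC[C@H]4CO)c3Cl)c2n1`), which has hydroxymethyl in place of the carbamoyl of compound 3 on a saturated ring carbon: hydroxymethyl in place of carbamoyl on a saturated ring carbon. For the measured compounds named here, only one measured step touches this group, with hydrogen in place of methyl on the amide nitrogen: a 9.1-fold higher number from compound 1 to compound 3 (0.96 log units; beyond the scatter). This modest step shows that this assay can respond to a change at this group. Going by the values given here, it does not show what removing the carbamoyl does, and no measured compound carries hydroxymethyl.

The direction therefore remains uncertain. A lower number is the more likely outcome, as compound 3 at 12600 mL/min/kg sits at the top of the measured range. The expected change, smaller than the measured step, is a 2.1-fold lower number from compound 3 to compound 4 (0.32 log units; beyond the scatter). For compound 4 the estimated clearance is 6000 mL/min/kg, with an expected range of 1800 mL/min/kg to 18000 mL/min/kg.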

Compound 4, clearance: 1630 mL/min/kg
For compound 4 the middle estimate is 3.7-fold (0.57 log units) above the measured one; measured number outside the range, below it.
By their numbers in this assay, from the lowest: compounds 2, 1 and 4 (each within the scatter of the next, the first and the last beyond it); then compound 3.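

Moving from carbamoyl to hydroxymethyl on the saturated ring carbon gives a 7.7-fold lower number from compound 3 to compound 4 (0.89 log units; beyond the scatter) in this assay, which shows that the carbamoyl of compound 3 can be replaced at this position without keeping its very high clearance. Hydroxymethyl and methylcarbamoyl then read alike, with a 1.2-fold higher number from compound 1 to compound 4 (0.07 log units; within the scatter) on the same core, so that among these three compounds the unsubstituted carbamoyl alone stands apart, as the earlier 9.1-fold higher number from compound 1 to compound 3 (0.96 log units; beyond the scatter) had begun to suggest from a single step. The compounds shown offer no measurement that accounts for this separation.

As far as these compounds go, whether the gap between carbamoyl and hydroxymethyl persists on the core of compound 2 stays open, since that core carries neither hydroxymethyl nor the unsubstituted carbamoyl here. Also open, from the compounds shown here alone, is how clearance responds at this ring carbon to a carboxylic acid, an aminomethyl group, or a longer chain such as hydroxyethyl, and whether any of these falls clearly below the level shared by compound 1 and compound 4.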